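Notes on a benzyl-aniline urea series, step to compound 3

This account rests on a few compounds, and the source may have more. Where it says the series, first, only, none or still open, it means among the compounds named here.

Measured so far in a functional assay on SK-MEL-5 cells (Homo sapiens) for antiproliferative activity, read by sulforhodamine B assay, with a stated time of 48 h; on this read-out lower numbers stand for stronger inhibition of growth and higher numbers for weaker inhibition of growth:
compound 1, `Nc1nn(C(=O)Nc2ccc(Cc3ccccc3)cc2)c2ccccc12`: 8640 nM
compound 2, `Nc1nn(C(=O)Nc2ccc(Cc3ccccc3)cc2)c2ccc(Cl)cc12`: 21100 nM

Compound 2 gives the highest number of the two; the nearest is compound 1, separated by a 2.4-fold higher number from compound 1 to compound 2 (0.39 log units; beyond the scatter). Compound 3, `Nc1ccc2c(c1)c(N)nn2C(=O)Nc1ccc(Cc2ccccc2)cc1`, differs from compound 2 by amino in place of chloro on an aromatic carbon. Going by the values given here, the only step that bears on this position is a 2.4-fold higher number from compound 1 to compound 2 (0.39 log units; beyond the scatter), a modest change for chloro entering; amino at that carbon has no measured precedent here. The estimated step is therefore a 1.8-fold lower number from compound 2 to compound 3 (0.25 log units; within the scatter), expected to land between the two measured compounds. For compound 3 the expected value in this assay is 12000 nM, with a range from 5000 nM to 30000 nM.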

Compound 3, concentration for total growth inhibition: 19800 nM
Beside the measured number, compound 3's estimate is 1.7-fold (0.22 log units) below it; low and high end bracket the measured number.
By their numbers in this assay, from the lowest: compound 1; then compounds 3 and 2 (each within the scatter of the next).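

In this assay amino in place of chloro on this aromatic carbon gives a 1.1-fold lower number from compound 2 to compound 3 (0.03 log units; within the scatter) and so does not separate the two groups. Amino in place of hydrogen gives a 2.3-fold higher number from compound 1 to compound 3 (0.36 log units; beyond the scatter) and thus runs the same way as a 2.4-fold higher number from compound 1 to compound 2 (0.39 log units; beyond the scatter) for chloro. Both groups at this carbon therefore go against compound 1, even though amino brings a hydrogen-bond donor and acceptor that chloro lacks, and no supporting data bear on this result. Open, on these data alone, is whether methoxy or a carboxylic acid on this carbon would stay in the same range, or whether any group here would give a number lower than compound 1.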